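Pyridin-2-yl to 1H-Pyrazol-1-yl: Expected Solubility

A few compounds are considered here, and "the series" means these few. Any claim that something is new, unique, unknown or untested is made for them only; others in the source may bear on it.

Of the compounds shown here, three have been measured in a physicochemical assay for solubility, read by nephelometry, in phosphate buffer, measured as kinetic solubility, at pH 6.5; a higher number here means a more soluble compound, a lower number a less soluble compound. Compound 2 `Cc1cc(-c2ccccn2)cc(C(=O)NNS(=O)(=O)c2ccccc2)c1F` gives 6.3 ug/mL, and compound 1 `Cc1cc(-n2cccn2)cc(C(=O)NNS(=O)(=O)c2ccccc2)c1F` gives 6.3 ug/mL. The difference between the two is 1H-pyrazol-1-yl in place of pyridin-2-yl on an aromatic carbon, and the step of no change at the digits printed from compound 2 to compound 1 (within the scatter). Compound 3 `O=C(NNS(=O)(=O)c1ccccc1F)c1cccc(-c2ccccn2)c1` is built on a different core; how that core differs from the core of compound 2 is not broken down here. In this assay compound 3 gives 12.5 ug/mL, a number that stands within the scatter of both others.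

Compound 4 `O=C(NNS(=O)(=O)c1ccccc1F)c1cccc(-n2cccn2)c1` has not yet been measured. It differs from compound 3 by 1H-pyrazol-1-yl in place of pyridin-2-yl on an aromatic carbon. This is the same kind of change as that between compound 2 and compound 1, not the same: in compound 2 the place is also meta to a methyl group and para to a fluoro group, whereas in compound 3 it is only meta to a large group. Among the compounds with values here, the one earlier instance of this kind of change left the number unchanged. The expected step is therefore no change at the digits printed from compound 3 to compound 4 (within the scatter). Compound 4 is estimated at 12.5 ug/mL, with a likely range from 5 ug/mL to 30 ug/mL.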

Compound 4, solubility: 50 ug/mL
The estimate for compound 4 lay 4.0-fold (0.60 log units) below the measured number; measured number above the stated range.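

In this assay, 1H-pyrazol-1-yl in place of pyridin-2-yl gave a 4.0-fold higher number from compound 3 to compound 4 (0.60 log units; beyond the scatter) on one core, whereas the same kind of change gave no change at the digits printed from compound 2 to compound 1 (within the scatter) on the other, showing that the result of this change did not carry over between these two cores. The cores differ in more than one place, and two pairs cannot show which difference matters or predict the result on a third core. Nothing measured here explains why the two steps differ.

The compounds shown leave open whether the larger step on the core of compound 3 would remain with only a methyl group or only a fluoro group added to that core. They also leave open how an amine or a carboxylic acid, in the place held by 1H-pyrazol-1-yl, would read in this assay on either core.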